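The compounds below may be only part of what the source reports. "The series", "measured", "known", "first", "only" and "open" are said of these compounds alone.

Measured compounds:
compound 1 `c1ccc(-c2ccncc2)c(OCC2=NCCN2)c1`, < 100000 nM
compound 2 `Cc1cccc(-c2ccccc2OCC2=NCCN2)n1`, 126 nM

In a functional assay for activation of Alpha-1A adrenergic receptor (Homo sapiens), read by calcium flux (on this read-out higher numbers stand for an effect only at larger amounts of compound and lower numbers for an effect already at smaller amounts), compound 1 gives only a limit, < 100000 nM, so no number of its own is known; this is the limit of < 100000 nM in this assay, at which 1 of the 2 values shown sits. Compound 2 gives 126 nM in this assay. Compound 3 `c1ccc(-c2ccncn2)c(OCC2=NCCN2)c1` is not yet measured in this assay. It differs from compound 1 in one place: pyrimidin-4-yl in place of pyridin-4-yl on an aromatic carbon. Within the data shown here, no step between measured compounds sets the size of this change. Compound 3 is expected to give a measurable number, the expected step that the limit leaves unreadable from compound 1 to compound 3 in this assay pointing toward an effect at smaller amounts. Compound 3 is estimated at 3000 nM in this assay, within 300 nM to 30000 nM.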

Compound 3, half-maximal effective concentration: < 100000 nM
Compound 3 was reported as a limit; the forecaster's own chance of this, stated with the estimate: 25%; the middle value lies beyond the limit too.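

In this assay, among these compounds, compound 1 and compound 3 both stand only as limits, so no step between them can be read. On these data alone, whether pyrimidin-4-yl in place of pyridin-4-yl changes receptor activation at all remains open.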